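The source may hold more compounds than are shown below. What is called first, only, known or untested is meant among the compounds shown, and "the series" means these compounds.

In a functional assay on the whole organism (Hindlimb, strain albino) with Mus musculus as the target, in the maximal electroshock model, with a stated time of 0.5 h (on this read-out higher numbers stand for an effect only at larger amounts of compound and lower numbers for an effect already at smaller amounts), compound 1 (`Cc1ccc2nc(NC(=O)/C=C/OC3=CC=C3)sc2c1`) gives 505 umol/kg and compound 2 (`O=C(/C=C/OC1=CC=C1)Nc1nc2ccc([N+](=O)[O-])cc2s1`) gives 597 umol/kg. Compound 3 (`O=C(/C=C/c1ccc(Cl)cc1)Nc1nc2ccccc2s1`) gives 367 umol/kg, which lies within the scatter of both. Compound 4 (`O=C(/C=C/c1ccc(Cl)cc1)Nc1nc2ccc(Cl)cc2s1`) differs from compound 3 by one change: chloro in place of hydrogen on an aromatic carbon. For the measured compounds named here, the one measured step that bears on this is a 1.2-fold higher number from compound 1 to compound 2 (0.07 log units; within the scatter), nitro in place of methyl on the same aromatic carbon of the core, and it stays within the scatter. The other end of compounds 1 and 2 differs from that of compound 3, so this is only an indirect guide. The expected change is a 1.0-fold lower number from compound 3 to compound 4 (0.02 log units; within the scatter), none beyond the scatter. For compound 4 the estimate is 350 umol/kg, with an expected range of 170 umol/kg to 720 umol/kg.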

Compound 4, dose for half-maximal effect: 204 umol/kg
Estimate against measurement, compound 4: 1.7-fold (0.23 log units) above; the measured number falls inside the stated range.
By their numbers in this assay, from the lowest: compounds 4, 3, 1 and 2 (each within the scatter of the next, the first and the last beyond it).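

With the other end held constant, chloro in place of hydrogen on this aromatic carbon of the shared core gives a 1.8-fold lower number from compound 3 to compound 4 (0.26 log units; within the scatter) in this assay, the first direct reading against hydrogen at this position, and it stays inside the scatter. The earlier step compared only methyl with nitro there, not either group with hydrogen. Nothing available here offers an explanation for this step. Going by these compounds, whether an amine or a carboxylic acid on this carbon would also stay within the scatter of hydrogen remains open, as does whether chloro would do so with the other end of compound 1 and compound 2.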